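This account rests on a few compounds, and the source may have more. Where it says the series, first, only, none or still open, it means among the compounds named here.

Measured compounds:
compound 1 `Cn1c(-c2cccc(C#N)c2)cnc1NC(=O)c1ccc(F)cc1`, > 100000 nM
compound 2 `Cn1c(-c2cccc(C#N)c2)cnc1NC(=O)c1ncc[nH]1`, > 50000 nM
compound 3 `COc1ccc(-c2cnc(NC(=O)C3CCOCC3)n2C)cc1`, > 100000 nM

In a toxicity assay on THP-1 cells (Homo sapiens) for inhibition (a lower number here means that less compound is tolerated, a higher number that more compound is tolerated), compound 1 gives > 100000 nM, which is a limit of the assay and not a number. Compound 2 gives > 50000 nM, likewise a limit. Compound 3 gives > 100000 nM, again a limit. Among the measured compounds shown here, the only step measured, a step that the two limits leave unreadable from compound 1 to compound 2, changes a different place and its two limits leave it unreadable. All three values sit at limits, as the limit of > 100000 nM in this assay, at which 2 of the 3 values shown sit, and the limit of > 50000 nM in this assay, at which 1 of the 3 values shown sits, show.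

Compound 4 `Cc1ccc(-c2cnc(NC(=O)c3ccc(F)cc3)n2C)cc1` differs from compound 1 by 4-methylphenyl in place of 3-cyanophenyl on an aromatic carbon. For the measured compounds named here, no measured step bears on this change, so no direction can be read. Compound 4 is expected at 100000 nM, between 30000 nM and 300000 nM, an estimated step of a number no higher from compound 1 to compound 4 (the limit leaves the size open), and the result is expected to be reported again only as a limit.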

Compound 4, half-maximal cytotoxic concentration: 60000 nM
For compound 4 the middle estimate is 1.7-fold (0.22 log units) above the measured one; the range from low to high includes it.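

Among the compounds shown here, compound 4 gives the first value in this assay that is a number and not a limit, so a change on this aromatic carbon can now be given a lower bound on its size. Taking 4-methylphenyl in place of 3-cyanophenyl gives an at least 1.6-fold lower number from compound 1 to compound 4 (0.22 log units; that floor lies within the scatter). That floor lies within the usual scatter, so this change is not shown to matter.

From the compounds shown here alone, how an amine or a carboxylic acid on this phenyl ring would read stays open. Whether 4-methylphenyl also gives a number when combined with the 1H-imidazol-2-yl of compound 2 is open too.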